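Fluoro in place of methyl on the lowest-number compound

The compounds below may be only part of what the source reports. "The series", "measured", "known", "first", "only" and "open" are said of these compounds alone.

In a functional assay on HCT-116 cells (Homo sapiens) for inhibition, read by MTT assay, with a stated time of 48 h (on this read-out lower numbers stand for stronger inhibition and higher numbers for weaker inhibition), compound 1 (`COc1ccc(N(C)c2nc(C)nc3ccccc23)cc1OCCC[Se]C#N`) gives 852 nM and compound 3 (`COc1ccc(N(C)c2nc(C)nc3ccccc23)cc1C(=O)OCCC[Se]C#N`) gives 720 nM as its value. Compound 2 (`Cc1nc(N(C)c2ccc([Se]C#N)c(C)c2)c2ccccc2n1`) gives 13 nM as the lowest of the three numbers, and its distance to each of the other two lies beyond the scatter. Compound 4 (`Cc1nc(N(C)c2ccc([Se]C#N)c(F)c2)c2ccccc2n1`) is still unmeasured and has fluoro in place of methyl on an aromatic carbon of compound 2 (fluoro in place of methyl on an aromatic carbon). For the measured compounds named here, only one measured step links two compounds that differ in one place (a 1.2-fold lower number from compound 1 to compound 3 (0.07 log units; within the scatter)), and it lies within the scatter, but it involves a different exchange and offers no direct size for this one. Compounds 1 and 3 differ from compound 2 in more than one place, so their distance from it says nothing specific about methyl and fluoro. Compound 2 at 13 nM already stands lowest among the values seen, so a small rise in this assay is expected rather than a fall. The estimated change is a 1.5-fold higher number from compound 2 to compound 4 (0.19 log units; within the scatter) and no shift beyond the scatter is expected. For compound 4 the estimated value is 20 nM with an expected range from 6 nM to 70 nM as the likely span.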

Compound 4, half-maximal inhibitory concentration: 20 nM
Compound 4: middle estimate and measured number agree at the digits printed; measured number inside the range.
By their numbers in this assay, from the lowest: compounds 2 and 4 (each within the scatter of the next); then compounds 3 and 1 (each within the scatter of the next).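

this assay now holds a measured step at this position: with fluoro in place of methyl, on the aromatic carbon meta to a large group, the record reads a 1.5-fold higher number from compound 2 to compound 4 (0.19 log units; within the scatter) and gives the first reading on this exchange. For the compounds shown here, the only earlier step concerned another place and another exchange, so it could not show that the methyl of compound 2 can give way to a fluoro while the two compounds stay within the scatter of each other. Nothing given here accounts for the two groups reading alike at this position.

The compounds shown leave open whether a plain hydrogen, a chloro, a methoxy, a trifluoromethyl or an amine on the same aromatic carbon would also stay within the scatter of methyl and fluoro. They also leave open whether fluoro in place of methyl would read the same if a longer chain carrying the selenium and the nitrile stood in place of the group that carries them in compound 2 and compound 4.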